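Chain extension on the sulfur substituent of compound 2

The source may hold more compounds than are shown below. What is called first, only, known or untested is meant among the compounds shown, and "the series" means these compounds.

Compound 1 `O=c1c2ccccc2[se]n1-c1nc(SCc2ccccc2)n[nH]1` gives only a limit in an ADME assay on L929 cells (Mus musculus) for antiproliferative activity, read by CCK-8 assay, with a stated time of 48 h (on this read-out higher numbers stand for weaker inhibition and lower numbers for stronger inhibition), namely > 50000 nM. Among the measured compounds shown here, compound 2 `CCCSc1n[nH]c(-n2[se]c3ccccc3c2=O)n1` gives 31800 nM in this assay, and the one measured step is an at least 1.5-fold lower number from compound 1 to compound 2 (0.19 log units; that floor lies within the scatter), ethyl in place of phenyl on a saturated chain carbon bound to a sulfur. On the numbers shown, compound 2 holds the only value that is a number; the other entry is a limit, as given by the limit of > 50000 nM in this assay, at which 1 of the 2 values shown sits. Compound 3 `CCCCSc1n[nH]c(-n2[se]c3ccccc3c2=O)n1` carries methyl in place of hydrogen on a saturated chain carbon, three bonds along the chain from a sulfur. For the measured compounds named here, the sole measured step, from compound 1 to compound 2, concerns a different change on a saturated chain carbon bound to a sulfur and reaches only a floor that lies within the scatter, so it offers little guidance for a methyl added three bonds along the chain from a sulfur. The expected step is therefore a 1.1-fold lower number from compound 2 to compound 3 (0.06 log units; within the scatter), nothing beyond the scatter. Compound 3 is estimated at 28000 nM, within 11000 nM to 70000 nM in this assay.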

Compound 3, half-maximal inhibitory concentration: 30400 nM
Beside the measured number, compound 3's estimate is 1.1-fold (0.04 log units) below it; the measured number falls inside the stated range.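

Among the compounds shown here, compound 2 and compound 3 give the first pair of true numbers, and in this assay they cannot be told apart: the methyl on a saturated chain carbon, three bonds along the chain from a sulfur, gives a 1.0-fold lower number from compound 2 to compound 3 (0.02 log units; within the scatter). Propyl to butyl at this position therefore shifts the read-out by no more than the scatter, whereas propyl in place of phenyl gives only a floor, an at least 1.6-fold lower number from compound 1 to compound 3 (0.21 log units; that floor lies within the scatter). Compound 1 remains a limit and not a number: the limit of > 50000 nM in this assay, at which 1 of the 3 values shown sits.

With only propyl and butyl available as numbers, no trend with chain length can be stated. On these data alone, whether a longer chain such as hexyl, a branched chain such as isopropyl, or an amine or carboxylic acid at the chain end would move the number beyond the scatter stays open.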